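Tert-butoxy for tert-butyl: an expected clearance step

The source may report more compounds than this note shows. Statements on the series, on what has been measured and on what is new or still open speak of the compounds shown alone.

Values measured so far in an ADME assay on liver for metabolic stability, with Liver microsome (Homo sapiens) as the target, read by LC-MS, using microsomes (on this read-out lower numbers stand for slow clearance and higher numbers for fast clearance), are these
- Compound 1 `CC(C)(C)C[C@@H](O)C(=O)N1C[C@@H]2C[C@@H]2[C@H]1C(=O)NCc1cc(Cl)ccc1-n1cnnn1` gives 20 mL.min-1.g-1
- Compound 2 `CC(C)(C)[C@@H](O)C(=O)N1N=CC[C@H]1C(=O)NCc1cc(Cl)ccc1-n1cnnn1` gives < 12 mL.min-1.g-1 as a limit of the assay

Among the measured compounds shown here, compound 1 holds the only plain number in this small set, and the one other result is a limit. Compound 3 `CC(C)(C)OC[C@@H](O)C(=O)N1C[C@@H]2C[C@@H]2[C@H]1C(=O)NCc1cc(Cl)ccc1-n1cnnn1` keeps the core of compound 1 and differs from it in one place (tert-butoxy in place of tert-butyl on a saturated chain carbon, two bonds along the chain from a carbonyl carbon and an oxygen on a saturated carbon) with tert-butoxy in place of tert-butyl on a saturated chain carbon, two bonds along the chain from a carbonyl carbon and an oxygen on a saturated carbon. For the measured compounds named here, no measured pair shows a change of this kind, so the expectation rests only on compound 1 at 20 mL.min-1.g-1 and on the structural change itself. The expected size in this assay is a 1.1-fold lower number from compound 1 to compound 3 (0.05 log units; within the scatter) and this estimated step stays within the usual scatter, with no firm direction. The estimated value for compound 3 is 18 mL.min-1.g-1 (expected range 10 mL.min-1.g-1 to 34 mL.min-1.g-1).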

Compound 3, intrinsic clearance in microsomes: 37 mL.min-1.g-1
Compound 3: middle estimate off by 2.1-fold (0.31 log units), on the low side, and the stated range ends below it.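

In this assay, tert-butoxy in place of tert-butyl on a saturated chain carbon, two bonds along the chain from a carbonyl carbon and an oxygen on a saturated carbon, gives a 1.9-fold higher number from compound 1 to compound 3 (0.27 log units; within the scatter). Among the compounds shown here, this is the first pair in the set that differs in one place, so it gives the first direct reading at this position, and that reading separates the two groups by no more than repeated measurements of this kind usually do. Nothing measured here bears on what lies behind this step.

From the compounds shown here alone, whether an amine, a carboxylic acid or a longer chain on this carbon would give a step beyond the scatter stays open, as does whether the exchange of neopentyl for (tert-butoxy)methyl would give a step of similar size on another core. For the compounds shown here, compound 2 differs from compound 1 in more than one place and its result is a limit, so it adds no step at this position.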